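A few compounds are considered here, and "the series" means these few. Any claim that something is new, unique, unknown or untested is made for them only; others in the source may bear on it.

Measured so far in an ADME assay on Left cardiac atrium (Cavia porcellus); a lower number here means that less compound is needed, a higher number that more compound is needed for the effect:
compound 1 `CCOC(=O)C1=C(C)NC(C)=C(C(=O)OCC)C1c1c(-c2ccc(Cl)cc2)nc2sccn12` gives 97 nM
compound 2 `CCOC(=O)C1=C(C)NC(C)=C(C(=O)OCC)C1c1c(-c2ccc(Cl)cc2)nc2sc(Cl)cn12` gives 3500 nM
compound 3 `CCOC(=O)C1=C(C)NC(C)=C(C(=O)OCC)C1c1c(-c2ccc([N+](=O)[O-])cc2)nc2sc(F)cn12` gives 24 nM

Compound 2 stands with the highest number of the three in this assay. For the measured compounds named here, the one step in the set that reaches it, a 36-fold higher number from compound 1 to compound 2 (1.56 log units; beyond the scatter), is large and concerns the fused ring, not the phenyl ring. Compound 4 `CCOC(=O)C1=C(C)NC(C)=C(C(=O)OCC)C1c1c(-c2cc([N+](=O)[O-])c(Cl)cc2Cl)nc2sc(Cl)cn12` keeps that chloro on the fused ring and changes the phenyl ring: 2,4-dichloro-5-nitrophenyl in place of 4-chlorophenyl on an aromatic carbon. Going by the values given here, no measured step matches this change; compound 3 carries a nitro on its phenyl ring and shows a much lower number than compound 2, but it also differs on the fused ring, so it is not a single step. The expected step of a 2.3-fold lower number from compound 2 to compound 4 (0.37 log units; beyond the scatter) is therefore uncertain, leaning downward. Compound 4 is expected to give 1500 nM, within 300 nM to 8000 nM.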

Compound 4, half-maximal effective concentration: 81 nM
The estimate for compound 4 lay 19-fold (1.27 log units) above the measured number; the measured number lies below the stated range.
By their numbers in this assay, from the lowest: compound 3; then compounds 4 and 1 (each within the scatter of the next); then compound 2.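

In this assay, the group on this aromatic carbon proves to matter a great deal: with the chloro on the fused ring kept, 2,4-dichloro-5-nitrophenyl in place of 4-chlorophenyl gives a 43-fold lower number from compound 2 to compound 4 (1.64 log units; beyond the scatter), a large step. The high number of compound 2 therefore does not hold once this phenyl ring changes. Nothing at hand explains the size of this step. As far as these compounds go, the change alters several parts of the phenyl ring together, so the share of the nitro and of each chloro remains unknown. From the compounds shown here alone, how an amine or a carboxylic acid on this phenyl ring would behave also stays open.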